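A few compounds are considered here, and "the series" means these few. Any claim that something is new, unique, unknown or untested is made for them only; others in the source may bear on it.

Measured compounds:
- compound 1, `COc1cc2nc(-c3ccc(Cl)cc3)cc(OCCCN3CCC(O)CC3)c2cc1OC` — in a functional assay on PC-3 cells (Homo sapiens) for inhibition, read by sulforhodamine B assay, with a stated time of 48 h (a higher number here means a weaker inhibitor of growth, a lower number a stronger inhibitor of growth), compound 1 gives 2020 nM
- compound 2, `COc1cc2nc(-c3ccc(C(F)(F)F)cc3)cc(OCCCN3CCCCC3)c2cc1OC` — in this assay compound 2 gives 1340 nM

Among the compounds with values here, compound 2 stands with the lower of the two numbers so far, but the gap to compound 1 lies within the scatter, so the two cannot be ranked against each other. The two compounds differ in two places at once, the group on the pendant aromatic ring and the saturated ring on the side chain, so no single-change step can be read from them.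

Compound 3, `COc1cc2nc(-c3ccc(C(F)(F)F)cc3)cc(OCCCN3CCC(O)CC3)c2cc1OC`, keeps the trifluoromethyl group of compound 2 and changes only the saturated ring: hydroxy in place of hydrogen on a saturated ring carbon. Within the data shown here, no measured pair isolates this change. The expectation is a step from compound 2 to compound 3 of a 1.3-fold higher number from compound 2 to compound 3 (0.13 log units; within the scatter), at most a slight move toward a weaker inhibitor and not clearly beyond the scatter, because compound 1 gives 2020 nM while also carrying the hydroxy group. Compound 3 is thus estimated at 1800 nM in this assay, with a range from 700 nM to 4500 nM.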

Compound 3, concentration for 50% growth inhibition: 3660 nM
Beside the measured number, compound 3's estimate is 2.0-fold (0.31 log units) below it; low and high end bracket the measured number.
By their numbers in this assay, from the lowest: compounds 2, 1 and 3 (each within the scatter of the next, the first and the last beyond it).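

In this assay, within the data shown here, with the trifluoromethyl group held fixed, replacing piperidin-1-yl with 4-hydroxypiperidin-1-yl gives a 2.7-fold higher number from compound 2 to compound 3 (0.44 log units; beyond the scatter), a modest move toward a weaker inhibitor and the first single-change reading at this saturated ring carbon, three ring bonds from the ring nitrogen. With 4-hydroxypiperidin-1-yl held fixed, trifluoromethyl in place of chloro on the aromatic carbon gives a 1.8-fold higher number from compound 1 to compound 3 (0.26 log units; within the scatter), which stays within the scatter, so this pair does not separate the two aromatic substituents. No measurement here bears on what lies behind the hydroxy step.

Going by these compounds, the hydroxy step is read only in the trifluoromethyl series, so its size with chloro on the aromatic ring remains open. Also open, on these data alone, is whether the loss follows from this particular group or from any substituent at this ring carbon: a methoxy group, an amine or a carboxylic acid in place of the hydroxy would address that, and a longer chain between the core and the ring would test how the step depends on the ring's distance from the core.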